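Benzothiophene in Place of Tolyl on the Thioether Arm

The source may report more compounds than this note shows. Statements on the series, on what has been measured and on what is new or still open speak of the compounds shown alone.

In a functional assay on MCF7 cells (Homo sapiens) for inhibition, read by MTT assay, with a stated time of 72 h (on this read-out lower numbers stand for stronger inhibition and higher numbers for weaker inhibition), compound 2 `Cc1ccc(CSc2nc3nc(C)cc(Nc4cc(-c5ccccc5)[nH]n4)n3n2)cc1` gives 7290 nM. Compound 1 `Cc1cc(Nc2ccn(Cc3cccc4ccccc34)n2)n2nc(SCc3ccc(Br)cc3)nc2n1` gives 4310 nM in this assay, a value that sits within the usual scatter of compound 2. For compound 3 `Cc1cc(Nc2cc(-c3ccccc3)[nH]n2)n2ncnc2n1` this assay reports only a limit, > 50000 nM. The step of an at least 6.8-fold higher number from compound 2 to compound 3 (0.83 log units; beyond the scatter) shows that removing the whole thioether arm costs inhibition, and the size of that loss is bounded because of the limit of > 50000 nM in this assay, at which 1 of the 3 values shown sits. Compound 4 `Cc1cc(Nc2cc(-c3ccccc3)[nH]n2)n2nc(SCc3csc4ccccc34)nc2n1` differs from compound 2 by 1-benzothiophen-3-yl in place of 4-methylphenyl on a saturated chain carbon bound to a sulfur. Going by the values given here, no measured step alters this group while keeping the arm; compound 1 carries a different arm and a different group elsewhere. Compound 4 is therefore expected to give 5000 nM, between 2000 nM and 15000 nM. The step of a 1.5-fold lower number from compound 2 to compound 4 (0.16 log units; within the scatter) is expected to stay within the scatter.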

Compound 4, half-maximal inhibitory concentration: 3470 nM
Compound 4: the middle estimate sits 1.4-fold (0.16 log units) above what was measured, and the stated range covers the measured number.
By their numbers in this assay, from the lowest: compounds 4, 1 and 2 (each within the scatter of the next, the first and the last beyond it). At a limit, above all of these: compound 3.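

Replacing 4-methylphenyl with 1-benzothiophen-3-yl is the only step shown that keeps the thioether arm and alters its end group, and it gives a 2.1-fold lower number from compound 2 to compound 4 (0.32 log units; beyond the scatter). Against hydrogen, the ((1-benzothiophen-3-yl)methyl)sulfanyl arm gives an at least 14-fold lower number from compound 3 to compound 4 (1.15 log units; beyond the scatter), so a second arm also stands well clear of the compound without one. The value of compound 3 is a limit, so this step has only a bound: the limit of > 50000 nM in this assay, at which 1 of the 4 values shown sits.

As far as these compounds go, whether the shift follows the added ring or the sulfur stays open. So does what a naphthalen-1-yl group or an amine on the same chain carbon would give.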